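A few compounds are considered here, and "the series" means these few. Any claim that something is new, unique, unknown or untested is made for them only; others in the source may bear on it.

Among the compounds with values here, in a functional assay on MV4-11 cells (Homo sapiens) for antiproliferative activity, read by resazurin assay, with a stated time of 72 h (a lower number here means a stronger inhibitor of growth, a higher number a weaker inhibitor of growth), compound 1 `CC(=O)N1CCN(c2ccc(Nc3nccc(-c4c[nH]c5ccccc45)n3)cc2)CC1` gives 33 nM, the lowest of the three numbers measured so far. Compound 2 `CC(=O)N1CCN(c2ccc(Nc3nccc(-c4c[nH]c5cccnc45)n3)cc2)CC1` gives 420 nM, and compound 3 `CC(=O)N1CCN(c2ccc(Nc3nccc(-c4nn(C)c5ccccc45)n3)cc2)CC1` gives 181 nM. Both replace the 1H-indol-3-yl group, with a 13-fold higher number from compound 1 to compound 2 (1.10 log units; beyond the scatter) and a 5.5-fold higher number from compound 1 to compound 3 (0.74 log units; beyond the scatter). Compound 4 `CC(=O)N1CCN(c2ccc(Nc3ncc(C#N)c(-c4c[nH]c5ccccc45)n3)cc2)CC1` keeps that group and instead puts cyano in place of hydrogen on an aromatic carbon, ortho to the 1H-indol-3-yl group: cyano in place of hydrogen on an aromatic carbon. Within the data shown here, no measured step touches this position, so those two steps give no guide to the size or direction of this change. No shift beyond the scatter is therefore expected in this assay, and the expected step is a 1.2-fold higher number from compound 1 to compound 4 (0.08 log units; within the scatter), with wide uncertainty. For compound 4 the estimated value is 40 nM, with an expected range from 10 nM to 160 nM.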

Compound 4, concentration for 50% growth inhibition: 4 nM
Beside the measured number, compound 4's estimate is 10-fold (1.00 log units) above it; measured number outside the range, below it.
By their numbers in this assay, from the lowest: compound 4; then compound 1; then compound 3; then compound 2.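

This position, ortho to a 1H-indol-3-yl group, proves highly responsive in this assay: cyano in place of hydrogen gives an 8.3-fold lower number from compound 1 to compound 4 (0.92 log units; beyond the scatter) and so is the first change shown that lowers the number from compound 1. No measurement shown accounts for this step.

A single substituent cannot show whether a chlorine atom, a methyl group or a primary amide here would do the same. As far as these compounds go, it also remains open whether cyano would lower the numbers of compound 2 and compound 3.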